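From 4-chlorophenyl to 2,4-dihydroxyphenyl on a carbonyl carbon

This account rests on a few compounds, and the source may have more. Where it says the series, first, only, none or still open, it means among the compounds named here.

Measured in a functional assay on MCF7 cells (Homo sapiens) for inhibition, read by MTT assay, with a stated time of 72 h; on this read-out higher numbers stand for weaker inhibition and lower numbers for stronger inhibition:
Compound 1 `COc1cc(OC)c(OC)cc1/C=C/C(=O)c1ccc(Cl)cc1`: 29500 nM
Compound 2 `COc1cc(OC)c(-c2cc(=O)c3ccc(O)cc3o2)cc1OC`: > 150000 nM (a limit)
Compound 3 `COc1cc(OC)c(-c2cc(=O)c3cc(Cl)ccc3o2)cc1OC`: > 150000 nM (a limit)

Compound 1 is the only one of these with an actual number. Compound 2 and compound 3 give only a limit, (the limit of > 150000 nM in this assay, at which 2 of the 3 values shown sit).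

Compound 4 `COc1cc(OC)c(OC)cc1/C=C/C(=O)c1ccc(O)cc1O` keeps the core of compound 1 but carries 2,4-dihydroxyphenyl in place of 4-chlorophenyl on a carbonyl carbon. Among the compounds with values here, no measured pair shows this change on its own, so the only anchor in this assay is compound 1 at 29500 nM, and no shift beyond the scatter is expected. The expected step is small: a 1.5-fold lower number from compound 1 to compound 4 (0.17 log units; within the scatter). Compound 4 is estimated at 20000 nM, with an expected range of 6000 nM to 80000 nM.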

Compound 4, half-maximal inhibitory concentration: 33800 nM
The estimate for compound 4 lay 1.7-fold (0.23 log units) below the measured number; the range from low to high includes it.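

Putting 2,4-dihydroxyphenyl in place of 4-chlorophenyl on the carbonyl carbon gives a 1.1-fold higher number from compound 1 to compound 4 (0.06 log units; within the scatter) in this assay. This single measured pair shows that, at this place on the core of compound 1, a ring with hydrogen-bond donors can replace one with none and produce no readable change. No measured property shown here bears on this result.

Still open, on these data alone, is whether a different group at this place, such as an amine or a carboxylic acid on the ring, would shift the number beyond the scatter.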